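The compounds below may be only part of what the source reports. "The series", "measured", "known", "first", "only" and "open" are said of these compounds alone.

Measured so far in a functional assay on K562 cells (Homo sapiens) for cytotoxicity, read by MTT assay, with a stated time of 48 h; on this read-out lower numbers stand for stronger inhibition and higher numbers for weaker inhibition:
- compound 1 `O=C(CN[C@H]1CCN(S(=O)(=O)Cc2ccccc2)C1)N1CCN(Cc2ccc(Cl)cc2)CC1`: 9200 nM
- compound 2 `O=C(CN[C@H]1CCN(S(=O)(=O)Cc2ccccc2)C1)N1CCN(Cc2cccc(F)c2)CC1`: 13200 nM

Among the compounds with values here, with only two numbers available, the position of compound 2 is easy to state: it cannot be separated from the one other measured compound. Within the data shown here, the single measured step is a 1.4-fold higher number from compound 1 to compound 2 (0.16 log units; within the scatter).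

Compound 3 `O=C(CN[C@H]1CCN(S(=O)(=O)Cc2ccccc2)C1)N1CCN(Cc2ccc(F)cc2)CC1` has not yet been measured. Its structural change is 4-fluorophenyl in place of 3-fluorophenyl on a saturated chain carbon bound to an amine nitrogen in a ring. In words, a 4-fluorophenyl stands in place of the 3-fluorophenyl, on a saturated chain carbon bound to an amine nitrogen in a ring. The rest of the structure stays the same.

Among the measured compounds shown here, no measured step shows this exact swap, so only one step bears on it. That step, a 1.4-fold higher number from compound 1 to compound 2 (0.16 log units; within the scatter), changed the same group and did not move the number beyond the scatter. This is thin evidence, but it gives no reason to expect a large change in this assay, and no direction can be predicted with confidence. The expected step is therefore small and within the scatter: a 1.2-fold lower number from compound 2 to compound 3 (0.08 log units; within the scatter). For compound 3 the estimated value is 11000 nM, with an expected range from 6000 nM to 20000 nM.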

Compound 3, half-maximal inhibitory concentration: 14300 nM
Compound 3: middle estimate off by 1.3-fold (0.11 log units), on the low side; the measured number falls inside the stated range.
By their numbers in this assay, from the lowest: compounds 1, 2 and 3 (each within the scatter of the next).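

In this assay, the 4-fluorophenyl in place of the 3-fluorophenyl, on a saturated chain carbon bound to an amine nitrogen in a ring, gives a 1.1-fold higher number from compound 2 to compound 3 (0.03 log units; within the scatter), so this change in where the fluorine sits cannot be told apart from repeat-measurement noise. Fluoro in place of chloro on an aromatic carbon gives a 1.6-fold higher number from compound 1 to compound 3 (0.19 log units; within the scatter), which is also within the scatter; the earlier step had changed the halogen and its place together, and each change can now be read alone, with neither separating the compounds in this assay. No supporting data are available to explain these results.

The compounds shown carry only a fluoro or a chloro on this aromatic ring, so it remains open whether a methoxy group, a carboxylic acid or an amine there, or a ring with no substituent at all, would move the number beyond the scatter. The rest of the structure is the same in all three compounds, so they also say nothing about how the number responds to a change elsewhere in the shared core.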